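Cytotoxicity on THP-1 cells: amide variation of compound 2

A few compounds are considered here, and "the series" means these few. Any claim that something is new, unique, unknown or untested is made for them only; others in the source may bear on it.

Measured compounds:
compound 1 `COc1ccc2nc(NC(=O)c3ccc(F)cc3)n(C)c2c1`: > 100000 nM
compound 2 `COc1ccc(-c2cnc(NC(=O)c3ccccn3)n2C)cc1`: > 100000 nM
compound 3 `Cn1c(-c2ccccc2)cnc1NC(=O)c1ccccc1Cl`: > 50000 nM

In a toxicity assay on THP-1 cells (Homo sapiens) for inhibition (a lower number here means that less compound is tolerated, a higher number that more compound is tolerated), compound 1 gives only a limit, > 100000 nM. Compound 2 likewise gives a limit, > 100000 nM, in this assay. Compound 3 gives a limit as well, > 50000 nM. Compound 2 thus stands at the limit of > 100000 nM in this assay, at which 2 of the 3 values shown sit, with compound 3 at the limit of > 50000 nM in this assay, at which 1 of the 3 values shown sits; no number separates any of the three.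

Compound 4 `COc1ccc(-c2cnc(NC(=O)c3cnc[nH]3)n2C)cc1` differs from compound 2 as follows: 1H-imidazol-5-yl in place of pyridin-2-yl on a carbonyl carbon. For the measured compounds named here, no step between measured compounds reports what such a change does in this assay, so no shift beyond the scatter is expected, and the estimated step from compound 2 to compound 4 is a number no higher from compound 2 to compound 4 (the limit leaves the size open). Compound 4 is expected to give about 100000 nM, in the range 50000 nM to 200000 nM, most likely again reported as a limit.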

Compound 4, half-maximal cytotoxic concentration: > 100000 nM
Compound 4 was reported as a limit (the forecaster's own chance of this, stated with the estimate: 85%); the middle value sits exactly at the limit.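

In this assay, for the compounds shown here, compound 2 and compound 4 both give only limits, so no step between them can be read. The compounds shown leave open the actual half-maximal cytotoxic concentration of each of the four.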